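The compounds below may be only part of what the source reports. "The series", "measured", "known", "first", "only" and "open" are said of these compounds alone.

Measured compounds:
Compound 1 `CNc1ncnc2c1c(-c1cccs1)cn2[C@@H]1O[C@H](CO)[C@@H](O)[C@H]1O` gives > 100000 nM in an ADME assay on MRC5 cells (Homo sapiens), read by MTT assay, with a stated time of 72 h (a lower number here means a stronger inhibitor, a higher number a weaker inhibitor), a limit of the assay rather than a number.
Compound 2 `Nc1nc(N)c2c(-c3cccs3)cn([C@@H]3O[C@H](CO)[C@@H](O)[C@H]3O)c2n1` gives > 100000 nM in this assay, again a limit and not a number.
Compound 3 `CNc1ncnc2c1c(-c1ccoc1)cn2[C@@H]1O[C@H](CO)[C@@H](O)[C@H]1O` gives > 100000 nM in this assay, also a limit.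

Compound 1 and compound 3 differ by furan-3-yl in place of thiophen-2-yl on an aromatic carbon, and that change gave a step that the two limits leave unreadable from compound 1 to compound 3. Compound 4 `Nc1nc(N)c2c(-c3ccoc3)cn([C@@H]3O[C@H](CO)[C@@H](O)[C@H]3O)c2n1` carries the same change on compound 2, (furan-3-yl in place of thiophen-2-yl on an aromatic carbon), at the same place. How the cores of compound 1 and compound 2 differ is not broken down here. Because (the limit of > 100000 nM in this assay, at which 3 of the 3 values shown sit), every measured value sits at the same limit, so the change is expected to leave compound 4 there as well: the step from compound 2 to compound 4 is expected to be a step that the limit leaves unreadable from compound 2 to compound 4. Compound 4 is therefore estimated at 150000 nM, most likely again reported only as a limit, between 50000 nM and 500000 nM.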

Compound 4, half-maximal inhibitory concentration: > 100000 nM
Compound 4 was reported as a limit; the forecaster's own chance of this, stated with the estimate: 90%; the middle value does not contradict the limit.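

Within the data shown here, compound 2 and compound 4 both give only a limit in this assay, so no step between them can be read. The compounds shown leave open whether any of these changes alters the true values, since all rest at one point: the limit of > 100000 nM in this assay, at which 4 of the 4 values shown sit.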